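The source may hold more compounds than are shown below. What is called first, only, known or untested is meant among the compounds shown, and "the series" means these compounds.

Measured so far in this series:
compound 1, `O=S(=O)(CC1=NCCO1)c1n[nH]cc1-c1ccccc1`, which in a functional assay, read by Griess assay, with a stated time of 150 min, tested at 75 ug/mL (a higher number here means a stronger effect of the compound at the concentration tested, a lower number a weaker effect), gives 54.7%
compound 2, `COc1ccc(C2=NOC(c3ccc(C)cc3)C2S(=O)(=O)CC2=NCCO2)cc1`, which in this assay gives 65.9%

Compound 2 stands highest of the two numbers; compound 1 is the nearest, and its number sits lower by a gap that lies beyond the usual scatter. For the measured compounds named here, no pair of measured compounds differs in one place only, so no single-change step is at hand to guide the next move.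

Compound 3, `COc1ccc(C2=NOC(c3ccc(C)cc3)C2S(=O)(=O)CC2=NCCS2)cc1`, is still to be measured in this assay. It differs from compound 2 as follows: a group of 5 heavy atoms (3 carbon, 1 nitrogen, 1 sulfur; one five-membered non-aromatic ring with 2 hetero atoms) in place of a group of 5 heavy atoms (3 carbon, 1 nitrogen, 1 oxygen; one five-membered non-aromatic ring with 2 hetero atoms), on a saturated chain carbon bound to a sulfonyl sulfur.

Nothing measured here speaks for or against this exchange, so the step is expected to be small, in either direction or none beyond the scatter; the expected step is a number 2.9 percentage points lower from compound 2 to compound 3 (within the scatter). The estimate for compound 3 in this assay is 63%, with a range from 45% to 80%.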

Compound 3, a percentage reported as activity, at one concentration (the size of the read-out at that concentration, not a potency): 54.1%
Compound 3: middle estimate off by 8.9 percentage points, on the high side; the measured number falls inside the stated range.
By their numbers in this assay, from the lowest: compounds 3 and 1 (each within the scatter of the next); then compound 2.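

For the compounds shown here, on a saturated chain carbon bound to a sulfonyl sulfur, the group cannot be exchanged freely in this assay: sulfur in place of oxygen in the five-membered non-aromatic ring gives a number 11.8 percentage points lower from compound 2 to compound 3 (beyond the scatter), the first single-change step. The two groups match in heavy-atom count, double bonds outside aromatic rings, hydrogen-bond donors and acceptors, and net charge, so this position responds to a change that these counts do not register. Nothing at hand accounts for the size or direction of the step.

Going by these compounds, whether the same exchange gives a comparable step on the core of compound 1 remains open. So does the read-out with an amine or a carboxylic acid in place of the five-membered ring on this chain carbon.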